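From compound 1 to compound 3: hydrogen for bromo

The source may report more compounds than this note shows. Statements on the series, on what has been measured and on what is new or still open speak of the compounds shown alone.

Measured in a physicochemical assay for solubility, read by HPLC, at pH 4; on this read-out higher numbers stand for higher solubility and lower numbers for lower solubility:
Compound 1 `O=C(Nc1ccc(F)cc1)N1N=C(c2ccc(Br)cc2)CC1c1ccc(F)cc1`: < 1 ug/mL
Compound 2 `COc1ccc(NC(=O)N2N=C(c3ccc(Br)cc3)CC2c2ccc(F)cc2)cc1`: < 1 ug/mL

Compound 1 stands at < 1 ug/mL, which is a limit and not a number. Compound 2 gives < 1 ug/mL, which is also a limit. Together they show (the limit of < 1 ug/mL in this assay, at which 2 of the 2 values shown sit).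

Compound 3 `O=C(Nc1ccc(F)cc1)N1N=C(c2ccccc2)CC1c1ccc(F)cc1` differs from compound 1 by hydrogen in place of bromo on an aromatic carbon. Within the data shown here, the only measured step is a different change, methoxy in place of fluoro on an aromatic carbon, and a step that the two limits leave unreadable from compound 1 to compound 2 offers no size to carry over. No step beyond the scatter is therefore expected in this assay. The expected step is a number no lower from compound 1 to compound 3 (the limit leaves the size open). Compound 3 is estimated at 1 ug/mL, with an expected range of 0.5 ug/mL to 3 ug/mL.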

Compound 3, solubility: < 1 ug/mL
Compound 3: a limit, no number; the forecaster's own chance of this, stated with the estimate: 60%; the middle value sits exactly at the limit.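

In this assay compound 3 gives < 1 ug/mL, which is a limit and not a number, so no step from compound 1 to compound 3 can be read: the limit of < 1 ug/mL in this assay, at which 3 of the 3 values shown sit.

The compounds shown leave open what size of step, if any, either hydrogen in place of bromo or methoxy in place of fluoro gives in this assay.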